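The source may report more compounds than this note shows. Statements on the series, on what has been measured and on what is new or still open speak of the compounds shown alone.

Measured in a functional assay on CEM-DNR-bulk cells (Homo sapiens), read by MTT assay, with a stated time of 72 h; on this read-out higher numbers stand for weaker inhibition and lower numbers for stronger inhibition:
- Compound 1 `CSc1ncnc2c1c(-c1cccs1)cn2[C@@H]1O[C@H](CO)[C@@H](O)[C@H]1O`: > 20000 nM
- Compound 2 `CSc1ncnc2c1c(-c1ccccc1)cn2[C@@H]1O[C@H](CO)[C@@H](O)[C@H]1O`: > 20000 nM
- Compound 3 `CNc1ncnc2c1c(-c1ccco1)cn2[C@@H]1O[C@H](CO)[C@@H](O)[C@H]1O`: > 20000 nM

All three entries are limits of the assay and not numbers. Compound 3 therefore has no measured potency to start from, and its value of > 20000 nM is a limit. The other two compounds share that position, as the limit of > 20000 nM in this assay, at which 3 of the 3 values shown sit, shows.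

Compound 4 `CNc1ncnc2c1c(-c1ccsc1)cn2[C@@H]1O[C@H](CO)[C@@H](O)[C@H]1O` carries thiophen-3-yl in place of furan-2-yl on an aromatic carbon.

Within the data shown here, the only measured step, a step that the two limits leave unreadable from compound 1 to compound 2, has no readable size, so it offers no magnitude to carry over. It also concerns a different exchange. Compound 1, which bears thiophen-2-yl, has a limit too, at > 20000 nM. Among the measured compounds shown here, no measured compound therefore points to a gain in this assay, and the expectation is that compound 4 will most likely stay at the limit, with a modest number possible. The expected step is a number no higher from compound 3 to compound 4 (the limit leaves the size open), with no direction beyond the scatter. The estimate for compound 4 is 20000 nM, with an expected range of 6000 nM to 25000 nM.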

Compound 4, half-maximal inhibitory concentration: > 20000 nM
Compound 4: no number, only a limit (the forecaster's own chance of this, stated with the estimate: 75%); the middle value sits exactly at the limit.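

Compound 3 and compound 4 both stand as limits of the assay and not as numbers, so no step can be read between them. The compounds shown leave open how any of these exchanges affects potency in this assay, for all share one position: the limit of > 20000 nM in this assay, at which 4 of the 4 values shown sit.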